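Compound 3: Bromo in Place of Fluoro

The source may report more compounds than this note shows. Statements on the series, on what has been measured and on what is new or still open speak of the compounds shown alone.

Compound 1 `CCOc1ccc(NC(=O)C2Cc3cc(OC)c(OC)cc3C2=O)cc1` gives 48.2 ug/mL
Compound 2 `COc1cc2c(cc1OC)C(=O)C(C(=O)Nc1ccc(F)cc1)C2` gives 55 ug/mL

In a physicochemical assay, with a stated time of 30 min (a lower number here means a stronger inhibitor, a higher number a weaker inhibitor), compound 1 gives 48.2 ug/mL and compound 2 gives 55 ug/mL as values within the scatter of each other, so neither can be ranked ahead of the other. The two compounds share one core and differ in a single substituent on the aromatic ring of the amide.

The next compound to be measured is compound 3 `COc1cc2c(cc1OC)C(=O)C(C(=O)Nc1ccc(Br)cc1)C2` and its change from compound 2 is bromo in place of fluoro on an aromatic carbon in short, bromo in place of fluoro on an aromatic carbon. Going by the values given here, only one measured step bears on this change: a 1.1-fold higher number from compound 1 to compound 2 (0.06 log units; within the scatter) for fluoro in place of ethoxy on an aromatic carbon. Among the compounds with values here, no compound carrying bromo has a measured value yet, so this single step is thin evidence. Even so, the one substituent swap seen so far moved this assay by no more than the scatter, and no larger shift is expected here. The expected size is a 1.1-fold lower number from compound 2 to compound 3 (0.02 log units; within the scatter) and this would be no change beyond the scatter. For compound 3 the estimated value is 52 ug/mL with an expected range from 25 ug/mL to 110 ug/mL as its likely span.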

Compound 3, half-maximal inhibitory concentration: 72.1 ug/mL
Beside the measured number, compound 3's estimate is 1.4-fold (0.14 log units) below it; low and high end bracket the measured number.
By their numbers in this assay, from the lowest: compounds 1, 2 and 3 (each within the scatter of the next).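

In this assay, the swap of one halogen for another at this aromatic carbon, para to a large group, gives a 1.3-fold higher number from compound 2 to compound 3 (0.12 log units; within the scatter), and the swap of ethoxy for bromo at the same place gives a 1.5-fold higher number from compound 1 to compound 3 (0.17 log units; within the scatter). The earlier pair had tied only ethoxy and fluoro, whereas the series now holds three substituents at this place, including a first pair of halogens, and each step among them stays within the scatter, so this position has not yet shown a substituent change that can be told apart from repeat variation in this assay. Nothing shown explains why the 4-fluorophenyl and 4-bromophenyl amides and their ethoxy counterpart read alike here.

Still open, from the compounds shown here alone, is whether a quite different group at this same aromatic carbon, such as an amine, a carboxylic acid or a chain longer than ethoxy, would move the number beyond the scatter. The compounds also leave open what a change elsewhere would do, for instance to the amide hydrogen or to the methoxy groups of the shared core, since all three compounds keep these parts unchanged.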